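The source may hold more compounds than are shown below. What is called first, only, known or untested is meant among the compounds shown, and "the series" means these compounds.

Among the compounds with values here, compound 2, `O=c1cc(-c2ccccc2)oc2ccc(N3COc4c(cccc4[N+](=O)[O-])C3)cc12`, stands at the top of the three numbers measured so far: in a functional assay on MCF7 cells (Homo sapiens) for inhibition, read by MTT assay, with a stated time of 48 h, tested at 30 ug/mL (on this read-out higher numbers stand for more inhibition of growth at the one concentration tested and lower numbers for less inhibition of growth), compound 2 gives 61.9%. Compound 1, `O=c1cc(-c2ccccc2)oc2cc(N3COc4ccccc4C3)ccc12`, gives 12.7% in this assay, which is a number well beyond the scatter below compound 2, and compound 3, `O=c1cc(-c2ccccc2)oc2cc(N3COc4c(Br)cccc4C3)ccc12`, gives 7.89%, the furthest from compound 2 of the three.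

Compound 4, `COc1cccc2c1OCN(c1ccc3oc(-c4ccccc4)cc(=O)c3c1)C2`, is the next compound to be measured in this assay. It differs from compound 2 in one place: methoxy in place of nitro on an aromatic carbon

Within the data shown here, no measured step replaces a nitro by a methoxy, so the change in compound 4 has no direct precedent. Among the measured compounds shown here, the only measured step is a number 4.8 percentage points lower from compound 1 to compound 3 (within the scatter), a change on an aromatic carbon of the same part of the core, and it stayed within the scatter. For the measured compounds named here, that step does not involve the nitro, and compound 2 is the only compound carrying it; its two neighbours, compound 1 and compound 3, both lack the nitro and both sit far lower, but they also differ from compound 2 in another place, so the nitro alone cannot be credited with the gap.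

On this evidence the account expects a downward step, a number 31.9 percentage points lower from compound 2 to compound 4 (beyond the scatter), with wide uncertainty, and estimates for compound 4 a value of 30%, in a range from 8% to 58%.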

Compound 4, percent growth inhibition at one concentration: 67.8%
The estimate for compound 4 lay 37.8 percentage points below the measured number; the whole stated range lies below it.
By their numbers in this assay, from the lowest: compounds 3 and 1 (each within the scatter of the next); then compounds 2 and 4 (each within the scatter of the next).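

In this assay, the step reads a number 5.9 percentage points higher from compound 2 to compound 4 (within the scatter), so on this aromatic carbon, ortho to a fused ring, the two groups cannot be told apart. Within the data shown here, this shows what the earlier compounds could not: the nitro is not needed for a reading of this size, since compound 4 carries methoxy in its place and stands level with compound 2, even though the exchange removes a double bond outside aromatic rings and one hydrogen-bond acceptor. No measurement presented here accounts for the two groups reading alike.

Compounds 1 and 3 each differ from compound 2 and compound 4 in more than one place, so what separates them from this pair remains unassigned by any single change. From the compounds shown here alone, it also remains open whether an amine, a carboxylic acid or a longer alkoxy chain on this same aromatic carbon would read like nitro and methoxy, or whether plain hydrogen there on the otherwise unchanged core of compound 2 would do so too.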